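The source may hold more compounds than are shown below. What is called first, only, known or untested is meant among the compounds shown, and "the series" means these compounds.

The series rests on the core of compound 1 `CCOC(=O)Cc1n[nH]c(N)n1`, which in a functional assay on the whole organism (strain albino) for inhibition, with Rattus norvegicus as the target, read by paw edema, with stated times of 30 min and 1 h, at a dose of 5 mg/kg by the oral route (on this read-out lower numbers stand for less inhibition and higher numbers for more inhibition at the one dose given (going by the name of the read-out)), gives 25%. Compound 2 `CCOC(=O)Cc1nc(N)n(C(=O)c2ccc(OC)cc2)n1` carries an acyl group on a ring nitrogen and in this assay gives 32.8%. Compound 3 `CCOC(=O)Cc1n[nH]c(NC(=O)c2ccc(Cl)cc2)n1` bears a chloro-substituted benzamide on the exocyclic nitrogen and in this assay gives 31.1%. The three numbers lie within the usual scatter of one another; compound 3 sits among them, nearest to compound 2 and furthest from compound 1, with neither gap beyond the scatter, so no ranking can be read from these figures.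

Compound 4 `CCOC(=O)Cc1n[nH]c(NC(=O)c2ccc([N+](=O)[O-])cc2)n1` differs from compound 3 in one place: nitro in place of chloro on an aromatic carbon. For the measured compounds named here, no measured pair isolates this exchange, so nothing measured tells how a nitro in place of chloro on an aromatic carbon moves the paw-edema read-out. Because compound 3 gives 31.1% and its neighbours stay within the scatter, the step is expected to be small, a number 1.1 percentage points lower from compound 3 to compound 4 (within the scatter), not beyond the scatter in either direction. For compound 4 the estimate in this assay is 30%, with a range from 18% to 42%.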

Compound 4, a percentage reported as inhibition, in the whole organism at one dose (the size of the read-out at that dose, not a potency): 32.6%
Compound 4: the middle estimate sits 2.6 percentage points below what was measured, within the range that was stated.
By their numbers in this assay, from the lowest: compounds 1, 3, 4 and 2 (each within the scatter of the next).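

In this assay, for the compounds shown here, nitro in place of chloro on an aromatic carbon, para to a large group, gives a number 1.5 percentage points higher from compound 3 to compound 4 (within the scatter) and is the first measured exchange at this position. The position therefore accepts nitro, with 3 heavy atoms and 2 hydrogen-bond acceptors, in place of chloro, with 1 heavy atom and no acceptors, without a step beyond the scatter. No supporting data bear on this step.

Open, on these data alone, is how an amine or a carboxylic acid at this position would move the paw-edema read-out, and whether the same exchange would behave alike with the acyl group on the ring nitrogen, as in compound 2. As far as these compounds go, with a single dose, it also remains open whether this step would stay within the scatter at other doses.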